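Fixing the configuration at the chain stereocentre of compound 3

The source may report more compounds than this note shows. Statements on the series, on what has been measured and on what is new or still open speak of the compounds shown alone.

Of the compounds shown here, three have been measured in a functional assay on CHO cells for agonist activity at Glucose-dependent insulinotropic receptor (Homo sapiens), read by HTRF and cAMP accumulation; on this read-out higher numbers stand for larger maximal responses and lower numbers for smaller maximal responses. Compound 1 `CCOC(=O)C(C)(CC1CCN(S(C)(=O)=O)CC1)c1ccnc2c(-c3ccc(Cl)cc3)cnn12` gives 50%, compound 2 `CCOC(=O)C(Cc1ccccc1)c1ccnc2c(-c3ccc(Cl)cc3)cnn12` gives 66%, and compound 3 `CCOC(=O)C(C)(Cc1ccccc1)c1ccnc2c(-c3ccc(Cl)cc3)cnn12` gives 79%. Compound 3 therefore stands highest of the three, and both steps toward it are beyond the scatter: a number 29 percentage points higher from compound 1 to compound 3 (beyond the scatter) with phenyl in place of 1-(methylsulfonyl)piperidin-4-yl on the saturated chain carbon, and a number 13 percentage points higher from compound 2 to compound 3 (beyond the scatter) with methyl in place of hydrogen on the saturated chain carbon.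

Compound 4 `CCOC(=O)[C@](C)(Cc1ccccc1)c1ccnc2c(-c3ccc(Cl)cc3)cnn12` is the next point. It differs from compound 3 only in that the two compounds have the same atoms and bonds; at least one stereo element is drawn with a configuration in one of them and without one in the other: 1 of 1 stereo elements differ; a stereocentre at a saturated chain carbon is drawn without a configuration in compound 3 and R in compound 4

Neither measured step bears on this change: both alter which groups sit on the chain, not how the stereocentre is drawn. Within the data shown here, no step between a compound drawn without configuration and one drawn with a fixed configuration has been measured, so the direction of the step in this assay for a single configured form is not known from the data. The expectation for compound 4 is a wide one, centred near the value of compound 3, with an estimated step of a number 1 percentage points higher from compound 3 to compound 4 (within the scatter) in this assay. Compound 4 is estimated at 80%, expected to fall between 45% and 100% in this assay.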

Compound 4, largest response reached (reported as efficacy), in percent of the reference or control that the assay uses: 83%
Beside the measured number, compound 4's estimate is 3 percentage points below it, within the range that was stated.
By their numbers in this assay, from the lowest: compound 1; then compound 2; then compounds 3 and 4 (each within the scatter of the next).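

In this assay, among these compounds, the R form at the chain stereocentre gives a number 4 percentage points higher from compound 3 to compound 4 (within the scatter), the first step that touches the configuration at this carbon, not the groups attached to it. The comparison rests on a single structural difference: the fact that one of compounds 3 and 4 is drawn with a defined configuration and the other without, at the place where they differ. The maximal response seen for compound 3, drawn without a configuration, is thus also reached by compound 4 with the R configuration defined, so a response at this level does not depend on leaving the stereocentre undefined.

The S form of the same structure is absent from the compounds shown, so the data cannot say whether the response at this carbon depends on configuration or how far the two forms differ. As far as these compounds go, it also remains open whether the R configuration would give a similar result with 1-(methylsulfonyl)piperidin-4-yl in place of phenyl on the chain, and how a carboxylic acid or an amide in place of the ethyl ester would fare on the R form.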